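Cytotoxicity notes on a chloroaryl prenyl ether pyrimidine series

The source may hold more compounds than are shown below. What is called first, only, known or untested is meant among the compounds shown, and "the series" means these compounds.

Measured so far in an ADME assay on MT2 cells (Homo sapiens) for cytotoxicity; on this read-out lower numbers stand for higher toxicity in this test and higher numbers for lower toxicity in this test:
Compound 1 `COc1nc(C)nc(Nc2ccc(Cl)c(OCC=C(C)C)c2)n1` gives 12000 nM
Compound 2 `CNc1ccnc(Nc2ccc(Cl)c(OCC=C(C)C)c2)n1` gives 690 nM
Compound 3 `COc1cc(OC)nc(Nc2ccc(Cl)c(OCC=C(C)C)c2)n1` gives 28000 nM

Compound 2 stands at the lowest of the three numbers, the most toxic of the set; compound 1 and compound 3 both sit above it by margins beyond the scatter. Compound 4 `CC(C)=CCOc1cc(Nc2ncccn2)ccc1Cl` is the next candidate for this assay. It differs from compound 2 by hydrogen in place of methylamino on an aromatic carbon. Among the measured compounds shown here, no measured pair covers this change, so the step is open. For the measured compounds named here, compound 2 is the only member carrying the methylamino group and the only one with a low number, which suggests the bare core may read less toxic. A moderate rise is expected, a 4.3-fold higher number from compound 2 to compound 4 (0.64 log units; beyond the scatter). Compound 4 is estimated at 3000 nM, within 800 nM to 15000 nM.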

Compound 4, half-maximal cytotoxic concentration: 2500 nM
Compound 4: middle estimate off by 1.2-fold (0.08 log units), on the high side, and the stated range covers the measured number.
By their numbers in this assay, from the lowest: compound 2; then compound 4; then compound 1; then compound 3.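

In this assay the change to hydrogen in place of methylamino on this aromatic carbon gives a 3.6-fold higher number from compound 2 to compound 4 (0.56 log units; beyond the scatter) on the number. Among the compounds shown here, this is the first step read between compounds that differ in one place, and it ties part of the low number of compound 2 to the methylamino group at this position. No measurement at hand explains the shift.

Still open, on these data alone, is whether an ethylamino or dimethylamino group here would read like methylamino or like hydrogen.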